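The source may hold more compounds than are shown below. What is called first, only, known or untested is meant among the compounds shown, and "the series" means these compounds.

In an assay on COS-1 cells for displacement of a labelled ligand from sodium-dependent dopamine transporter (Homo sapiens) (a higher number here means a weaker inhibitor, a lower number a stronger inhibitor), compound 3 `COC(=O)[C@@H]1CCCC[C@@H]1c1ccc(OC(F)(F)F)cc1` gives 1180000 nM, the highest of the three numbers at hand. Compound 1 `COC(=O)C1=C(c2ccc(C(C)(C)C)cc2)CCCC1` gives 605000 nM, which lies within the usual scatter of the number for compound 3, so no order between the two can be read. Compound 2 `COC(=O)C1=C(c2ccc(Cl)cc2)CCCCC1` gives 15000 nM, a far lower number and beyond the scatter. Compound 4 `COC(=O)[C@@H]1CCCC[C@@H]1c1ccc(C(F)(F)F)cc1` differs from compound 3 in one place: trifluoromethyl in place of trifluoromethoxy on an aromatic carbon. For the measured compounds named here, no measured pair shows this change, so its effect in this assay is unknown. For compound 4 the expected step is a 1.3-fold lower number from compound 3 to compound 4 (0.12 log units; within the scatter), no larger than the scatter and in no settled direction. Compound 4 is therefore estimated at 900000 nM in this assay, with a range from 300000 nM to 3000000 nM.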

Compound 4, inhibition constant: 222000 nM
Estimate against measurement, compound 4: 4.1-fold (0.61 log units) above, outside the stated range (below it).
By their numbers in this assay, from the lowest: compound 2; then compound 4; then compounds 1 and 3 (each within the scatter of the next).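

In this assay, trifluoromethyl in place of trifluoromethoxy on this aromatic carbon, para to a large group, gives a 5.3-fold lower number from compound 3 to compound 4 (0.73 log units; beyond the scatter). For the compounds shown here, this is the first pair here that differs in one place, and it shows that the number responds to this exchange at this position, though only modestly. No measurement at hand accounts for the step. Open, going by these compounds, is whether a nitrile or a methoxy group at this place would give a lower number still. Also open, on these data alone, is whether the same exchange would give a step of similar size on the core of compound 2.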